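The source may hold more compounds than are shown below. What is called first, only, known or untested is meant among the compounds shown, and "the series" means these compounds.

Working notes on the series. In a functional assay on A2780 cells (Homo sapiens) for cytotoxicity, read by MTT assay, with a stated time of 48 h (a lower number here means a stronger inhibitor, a higher number a weaker inhibitor), compound 2 `CN(C)CCCCN(C)C1=Nc2ccccc2C(CC(=O)NCc2ccccc2)N1c1ccc(-c2ccccc2)cc1` gives 1650 nM, the highest of the two numbers in hand. Its nearest neighbour is compound 1 `COc1ccc(CNC(=O)CC2c3ccccc3N=C(N(C)CCCCCN(C)C)N2c2ccc(-c3ccccc3)cc2)cc1`, which in this assay gives 1380 nM; the gap between compound 2 and compound 1 lies within the usual scatter, so the two values are read as equal. Nothing beyond those two values links the pair, as compound 1 and compound 2 differ in more than one place.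

Compound 3 `CN(C)CCCCCCN(C)C1=Nc2ccccc2C(CC(=O)NCc2ccccc2)N1c1ccc(-c2ccccc2)cc1` is the next compound to be run in this assay. The change from compound 2 is 2-(dimethylamino)ethyl in place of dimethylamino on a saturated chain carbon, four bonds along the chain from an amine nitrogen.

Going by the values given here, no measured step of this kind exists, so the size of the step is not anchored by a precedent. Compound 1 and compound 2 carry chains of different lengths and sit together within the scatter, which argues for a step of no more than the scatter from compound 2 to compound 3. For compound 3 the expected value in this assay is 1300 nM, with a range of 600 nM to 2800 nM, which corresponds to an expected step of a 1.3-fold lower number from compound 2 to compound 3 (0.10 log units; within the scatter).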

Compound 3, half-maximal inhibitory concentration: 1190 nM
Compound 3: the middle estimate sits 1.1-fold (0.04 log units) above what was measured, within the range that was stated.
By their numbers in this assay, from the lowest: compounds 3, 1 and 2 (each within the scatter of the next).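

In this assay, going by these compounds alone, the only measured step of this kind is a 1.4-fold lower number from compound 2 to compound 3 (0.14 log units; within the scatter), so 2-(dimethylamino)ethyl in place of dimethylamino on a saturated chain carbon, four bonds along the chain from an amine nitrogen, leaves the read-out unchanged within the scatter. The entering group holds 5 heavy atoms against 3 in the leaving group, with the same count of hydrogen-bond acceptors and donors, so at this position the added chain length alone gives no measurable change in this read-out. No measurement in hand bears on the reason for this result.

With a single step at this position, no trend with chain length can be claimed from these compounds. Still open, from the compounds shown here alone, are whether a chain longer than that of compound 3 keeps the value in the same range, and whether the terminal amine matters at all, which a hydroxyl or a carboxylic acid in place of dimethylamino on the same saturated chain carbon would test.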